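The compounds below may be only part of what the source reports. "The series", "measured", "known", "first", "only" and "open" are said of these compounds alone.

Compound 1, `O=C(N[C@H]1CCC[C@H](CO)C1)C1CCN(c2nc3cc(Cl)c(Cl)cc3o2)CC1`, gives 27.1 mL/min/kg in an ADME assay on microsomes from liver (Homo sapiens) for metabolic stability; a higher number here means faster removal of the compound, a lower number slower removal. Compound 2, `O=C(N[C@H]1CCC[C@H](CO)C1)C1CCN(c2nc3cc(Cl)c(C(F)(F)F)cc3o2)CC1`, gives 26.5 mL/min/kg in this assay. Compound 3, `CCOc1ccc(-c2cc3oc(N4CCC(C(=O)N[C@H]5CCC[C@H](CO)C5)CC4)nc3cc2Cl)cc1`, reaches only a limit of this assay, < 8 mL/min/kg.

Compound 3 thus stands at the low edge of what this assay reports (the limit of < 8 mL/min/kg in this assay, at which 1 of the 3 values shown sits), and only a limit, not a number, is known for it. Compound 4, `O=C(N[C@H]1CCC[C@H](CO)C1)C1CCN(c2nc3cc(Cl)c(-c4ccc(OC(F)(F)F)cc4)cc3o2)CC1`, differs from it by trifluoromethyl in place of ethyl on an oxygen on an aromatic ring. Among the compounds with values here, no measured step touches that oxygen. Within the data shown here, the steps that bear on the region are those leading into compound 3: an at least 3.3-fold lower number from compound 1 to compound 3 (0.52 log units; beyond the scatter) and an at least 3.3-fold lower number from compound 2 to compound 3 (0.52 log units; beyond the scatter), both at least modest and both beyond the scatter, each replacing a small group on the aromatic carbon with 4-ethoxyphenyl. The earlier exchange a 1.0-fold lower number from compound 1 to compound 2 (0.01 log units; within the scatter) lay within the scatter. Compound 4 keeps the aryl group that accompanied the drop to the limit and changes only the ethyl on its oxygen, so no step beyond the scatter is expected in this assay; a value near the limit, possibly again only a limit, is the estimate. Compound 4 is expected to give about 7 mL/min/kg, within 3 mL/min/kg to 16 mL/min/kg. The expected step is a step that the limit leaves unreadable from compound 3 to compound 4.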

Compound 4, clearance: 50.8 mL/min/kg
Beside the measured number, compound 4's estimate is 7.3-fold (0.86 log units) below it; the whole stated range lies below it.
By their numbers in this assay, from the lowest: compounds 2, 1 and 4 (each within the scatter of the next). At a limit, below all of these: compound 3.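

In this assay the group on the oxygen turns out to count for a great deal: trifluoromethyl in place of ethyl gives an at least 6.3-fold higher number from compound 3 to compound 4 (0.80 log units; beyond the scatter) and lies beyond the scatter, so the low reading of compound 3 does not carry over to every aryl group at this position. Within the data shown here, with 4-(trifluoromethoxy)phenyl on the aromatic carbon, a 1.9-fold higher number from compound 1 to compound 4 (0.27 log units; within the scatter) and a 1.9-fold higher number from compound 2 to compound 4 (0.28 log units; within the scatter) both stay within the scatter, so compound 4 cannot be told apart from the compounds that carry only chloro or trifluoromethyl there, and the earlier steps into compound 3 are now seen to depend on the ethoxy end of that aryl group and not on the added ring alone. Compound 3 is known only as a limit, so the full size of its step to compound 4 cannot be read: the limit of < 8 mL/min/kg in this assay, at which 1 of the 4 values shown sits.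

The compounds shown put only ethyl and trifluoromethyl on that oxygen, which leaves open how a methyl, a longer chain such as propyl, or a difluoromethyl would fall between these two readings. Going by these compounds, it also remains open whether an amine in place of that oxygen would keep the reading of compound 3 or join compound 4.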